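A few compounds are considered here, and "the series" means these few. Any claim that something is new, unique, unknown or untested is made for them only; others in the source may bear on it.

Measured so far:
compound 1 `O=c1cc(Cn2cc(CCCO)nn2)c2ccc(O)cc2o1`, 90200 nM in a functional assay on HeLa cells (Homo sapiens) for inhibition, read by MTT assay, with a stated time of 72 h; a lower number here means a stronger inhibitor, a higher number a weaker inhibitor
compound 2 `O=c1cc(Cn2cc(-n3ccc4cc(I)ccc43)nn2)c2ccc(O)cc2o1`, 14200 nM in this assay

Compound 2 has the lower of the two numbers, and compound 1 lies above it by a gap beyond the usual scatter. Compound 3 `Cc1ccc2c(Cn3cc(-n4ccc5cc(I)ccc54)nn3)cc(=O)oc2c1` differs from compound 2 in one place: methyl in place of hydroxy on an aromatic carbon. Among the measured compounds shown here, no measured pair shows this exchange, so its size is not known from these data. With one heavy atom swapped for one heavy atom, no step beyond the scatter is expected in this assay, in either direction. Compound 3 is therefore expected to give 12000 nM, within 4000 nM to 40000 nM, so that a 1.2-fold lower number from compound 2 to compound 3 (0.07 log units; within the scatter) is expected to stay inside the usual spread.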

Compound 3, half-maximal inhibitory concentration: 34400 nM
Compound 3: the middle estimate sits 2.9-fold (0.46 log units) below what was measured; measured number inside the range.
By their numbers in this assay, from the lowest: compound 2; then compound 3; then compound 1.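

In this assay, swapping just one atom at this position still matters: methyl in place of hydroxy gives a 2.4-fold higher number from compound 2 to compound 3 (0.38 log units; beyond the scatter) as a modest step beyond the scatter. The hydroxy, with its hydrogen-bond donor and acceptor, therefore goes with the lower number in this single pair, whereas methyl has neither. Nothing measured here explains the step.

Going by these compounds, it remains open whether an amine or a methoxy group at this position would behave like hydroxy or like methyl. The same exchange on the core of compound 1 is also unresolved.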